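This account rests on a few compounds, and the source may have more. Where it says the series, first, only, none or still open, it means among the compounds named here.

Compound 1 `CC(C)C[C@H](N)CN(C(=O)[C@@H]1C[C@H]1c1ccccc1)c1ccc(-c2ccccc2)cc1`: 880 nM
Compound 2 `CC[C@H](C)[C@H](N)CN(C(=O)[C@@H]1C[C@H]1c1ccc(Cl)cc1)c1ccc(-c2ccccc2)cc1`: 4300 nM

Both compounds were tested in a functional assay for agonist activity at G protein-coupled receptor 88 (Homo sapiens), read by HTRF and cAMP accumulation; on this read-out higher numbers stand for an effect only at larger amounts of compound and lower numbers for an effect already at smaller amounts. Of the two numbers, compound 2 gives the higher one, and the gap to compound 1 lies beyond the usual scatter of repeated measurements, so compound 2 is the weaker of the two in this assay. The two compounds differ in more than one place, so no single change can be held responsible for that gap.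

Compound 3 `CC[C@H](C)[C@H](N)CN(C(=O)[C@@H]1C[C@H]1c1cc(F)ccc1F)c1ccc(-c2ccccc2)cc1` has not yet been measured. It keeps the shared core of compound 2 and differs from it in one place only: 2,5-difluorophenyl in place of 4-chlorophenyl on a saturated ring carbon. Within the data shown here, no measured pair shows this particular change, so its effect cannot be read off from the numbers at hand. The expected step is a 1.4-fold lower number from compound 2 to compound 3 (0.16 log units; within the scatter), a modest move toward a lower number that may well stay within the scatter. Compound 3 is therefore estimated at 3000 nM, with a range from 800 nM to 12000 nM.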

Compound 3, half-maximal effective concentration: 770 nM
The estimate for compound 3 lay 3.9-fold (0.59 log units) above the measured number; measured number outside the range, below it.
By their numbers in this assay, from the lowest: compounds 3 and 1 (each within the scatter of the next); then compound 2.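

In this assay, putting 2,5-difluorophenyl in place of 4-chlorophenyl on this saturated ring carbon of the three-membered ring gives a 5.6-fold lower number from compound 2 to compound 3 (0.75 log units; beyond the scatter), so the read-out responds to what the aromatic ring at this position carries. Among these compounds, this is the first comparison here in which only one place changes, so this gap, unlike the one between compound 1 and compound 2, can be tied to a single exchange. That exchange removes the chlorine and brings in two fluorines at once, so the step belongs to the swap as a whole, and no evidence is available to explain why it goes in this direction.

Going by these compounds, it remains open whether either fluorine alone would give the same step, or whether a 2,5-dichlorophenyl group or a ring bearing a methoxy group would fit this position equally well. On these data alone, it is also open whether the same exchange would give a similar step on the side chain of compound 1, which differs from compound 2 in more than one place.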